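Cytotoxicity notes on a benzimidazole amide series, compound 3 pending

A few compounds are considered here, and "the series" means these few. Any claim that something is new, unique, unknown or untested is made for them only; others in the source may bear on it.

Compound 1 `CCN(CC)c1cc2[nH]c(C3CCCCC3)nc2cc1NC(=O)c1cnccn1` carries a (pyrazin-2-yl)carbonyl amide on the shared core. In an ADME assay on Vero cells (Chlorocebus sabaeus) for cytotoxicity, read by resazurin assay, with a stated time of 3 days (on this read-out higher numbers stand for weaker inhibition and lower numbers for stronger inhibition), compound 1 reports only a limit, > 100 ug/mL, not a number. Compound 2 `CCCCNC(=O)Nc1cc2nc(C3CCCCC3)[nH]c2cc1N(C)C` is a urea analogue on the same core. In this assay compound 2 likewise reports only a limit, > 100 ug/mL. So compound 1 stands at the limit of the assay, as every value so far does: the limit of > 100 ug/mL in this assay, at which 2 of the 2 values shown sit. Among the compounds with values here, no step between two numbered values exists, and no pattern can be drawn beyond that both measured compounds sit at the limit.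

Compound 3 `CCN(CC)c1cc2[nH]c(C3CCCCC3)nc2cc1NC(=O)c1cccc(Br)c1` differs from compound 1 in one place: 3-bromophenyl in place of pyrazin-2-yl on a carbonyl carbon. For compound 3 the expectation is a reading in the region of the limit again, with at most a shift within or slightly beyond the scatter in the direction of stronger inhibition, estimated as a number no higher from compound 1 to compound 3 (the limit leaves the size open). Compound 3 is therefore expected to give about 100 ug/mL, within a range of 40 ug/mL to 200 ug/mL, with a fair chance that this assay once more reports only a limit.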

Compound 3, half-maximal inhibitory concentration: > 100 ug/mL
Compound 3 was reported as a limit (the forecaster's own chance of this, stated with the estimate: 60%); the middle value lies on the limit itself.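

In this assay compound 3 gives > 100 ug/mL, a limit and not a number. With compound 1 also reported only as a limit, no step can be read between compound 1 and compound 3: the limit of > 100 ug/mL in this assay, at which 3 of the 3 values shown sit.

The compounds shown leave open whether 3-bromophenyl in place of pyrazin-2-yl changes cytotoxicity at all.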